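This account rests on a few compounds, and the source may have more. Where it says the series, first, only, none or still open, it means among the compounds named here.

Working notes on the series. In a functional assay on MDA-MB-231 cells (Homo sapiens), read by microscopy and transwell migration, with a stated time of 24 h (a lower number here means a stronger inhibitor, a higher number a weaker inhibitor), compound 1 `CCCn1c(-c2ccccc2)cs/c1=N\C(=O)c1ccccc1` gives 657 nM and compound 2 `O=C(Nc1nc(-c2ccccc2Cl)cs1)c1ccccc1` gives 15000 nM as the higher of the two numbers, with a gap beyond the scatter. Going by the values given here, compound 3 `O=C(Nc1nc(-c2cccc(Br)c2)cs1)c1ccccc1` is unmeasured, and 3-bromophenyl in place of 2-chlorophenyl on an aromatic carbon is its one difference from compound 2. Among the compounds with values here, no measured pair shows a change of this kind, so no step beyond the scatter is expected in this assay, with a slight lean towards a lower number. The expected change is a 1.9-fold lower number from compound 2 to compound 3 (0.27 log units; within the scatter) as an estimate only. For compound 3 the estimated value is 8000 nM with an expected range from 2000 nM to 30000 nM in this read-out.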

Compound 3, half-maximal inhibitory concentration: 10000 nM
Beside the measured number, compound 3's estimate is 1.3-fold (0.10 log units) below it, within the range that was stated.
By their numbers in this assay, from the lowest: compound 1; then compounds 3 and 2 (each within the scatter of the next).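

In this assay the first pair differing in one place gives a 1.5-fold lower number from compound 2 to compound 3 (0.18 log units; within the scatter). On the aromatic carbon next to the ring nitrogen, this exchange of 2-chlorophenyl for 3-bromophenyl, with equal heavy-atom counts, therefore does not separate the two compounds. No available evidence bears on this result.

On these data alone, whether an unsubstituted phenyl, or an aminophenyl or carboxyphenyl, at this position would shift the number remains open. As far as these compounds go, compound 1 differs from both compounds in more than one place, so which of its differences goes with its number also remains open.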